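Compound 3 in the antiproliferative series, with both neighbours at the limit

The source may hold more compounds than are shown below. What is called first, only, known or untested is meant among the compounds shown, and "the series" means these compounds.

Compounds measured so far in a functional assay on MT2 cells (Homo sapiens) for antiproliferative activity, read by MTT assay, with a stated time of 72 h (on this read-out lower numbers stand for stronger inhibition of growth and higher numbers for weaker inhibition of growth), are these two
Compound 1 `O=C(COc1c(-c2ccccc2)oc2ccccc2c1=O)Nc1ccc2ccccc2c1` gives > 10000 nM as a limit of the assay
Compound 2 `O=C(COc1c(-c2ccccc2)oc2ccccc2c1=O)Nc1ccc(F)cc1` gives > 10000 nM as a limit of the assay

In this assay compound 2 stands at > 10000 nM as a limit and not as a number. The whole record so far is the limit of > 10000 nM in this assay, at which 2 of the 2 values shown sit, and no measured number lies under it. The next compound is compound 3 `COc1ccc(NC(=O)COc2c(-c3ccccc3)oc3ccccc3c2=O)cc1` and its difference from compound 2 is methoxy in place of fluoro on an aromatic carbon with methoxy in place of fluoro on an aromatic carbon, para to a large group. Among the compounds with values here, the only measured step that bears on this is a step that the two limits leave unreadable from compound 1 to compound 2 and it gives no size to carry forward. Within the data shown here, no step of readable size points either way, so no change beyond the scatter is expected in this assay and compound 3 is expected to remain at the limit. The expected move is a step that the limit leaves unreadable from compound 2 to compound 3 in this estimate. For compound 3 the estimate is 12000 nM with an expected range of 6000 nM to 30000 nM if a number is reported at all.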

Compound 3, concentration for 50% growth inhibition: > 10000 nM
Compound 3: only a limit was reported (the forecaster's own chance of this, stated with the estimate: 85%); the middle value does not contradict the limit.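

No step among compound 1, compound 2 and compound 3 can be read in this assay, as all three stand at the same limit and not at a number: the limit of > 10000 nM in this assay, at which 3 of the 3 values shown sit.

The compounds shown leave open whether naphthalen-2-yl, 4-fluorophenyl and 4-methoxyphenyl on the amide-type nitrogen differ at all in this assay.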